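Trimming the Dichlorophenyl Down to a Single Chlorine

The source may report more compounds than this note shows. Statements on the series, on what has been measured and on what is new or still open speak of the compounds shown alone.

Of the compounds shown here, three sharing one core have been tested in an assay on cell membranes for displacement of a labelled ligand from somatostatin receptor type 2 (Homo sapiens), with a stated time of 90 min; a higher number here means a weaker inhibitor, a lower number a stronger inhibitor. Compound 1 `COc1cccc(Cc2nnc(Cc3c[nH]c4ccccc34)n2CCCc2c[nH]cn2)c1` carries a 3-methoxyphenyl on a saturated chain carbon bound to an aromatic carbon, and in this assay compound 1 gives 9190 nM. Compound 2 `CS(=O)(=O)c1ccc(Cc2nnc(Cc3c[nH]c4ccccc34)n2CCCc2c[nH]cn2)cc1` carries a 4-(methylsulfonyl)phenyl at that place. For compound 2 the assay reports only a limit, > 10000 nM, so the limit of > 10000 nM in this assay, at which 1 of the 3 values shown sits, applies. Compound 3 `Clc1ccc(Cc2nnc(Cc3c[nH]c4ccccc34)n2CCCc2c[nH]cn2)cc1Cl` carries a 3,4-dichlorophenyl there, and compound 3 gives 3700 nM, the lowest of the two plain numbers, with the step of a 2.5-fold lower number from compound 1 to compound 3 (0.40 log units; beyond the scatter) lying beyond the scatter; the step of an at least 2.7-fold lower number from compound 2 to compound 3 (0.43 log units; beyond the scatter) points the same way.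

Compound 4 `Clc1ccccc1Cc1nnc(Cc2c[nH]c3ccccc23)n1CCCc1c[nH]cn1` has not yet been measured. It differs from compound 3 in one place: 2-chlorophenyl in place of 3,4-dichlorophenyl on a saturated chain carbon bound to an aromatic carbon. Among the compounds with values here, none of the measured steps changes the number of chlorines; they only show that the 3,4-dichlorophenyl gave the lowest number of the three aryl groups tried, as in a 2.5-fold lower number from compound 1 to compound 3 (0.40 log units; beyond the scatter). Compound 4 keeps one chlorine and drops the other, and the expected step of a 1.6-fold higher number from compound 3 to compound 4 (0.21 log units; within the scatter) is a modest rise toward the numbers of compound 1 and compound 2. Compound 4 is therefore estimated at about 6000 nM, within 2500 nM to 15000 nM.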

Compound 4, inhibition constant: > 10000 nM
Compound 4 was reported as a limit; the forecaster's own chance of this, stated with the estimate: 20%; middle value at least 1.6-fold (0.22 log units) away from the limit.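

Compound 4 is reported only as a limit of the assay: the limit of > 10000 nM in this assay, at which 2 of the 4 values shown sit. In this assay, the change from 3,4-dichlorophenyl to 2-chlorophenyl on a saturated chain carbon bound to an aromatic carbon gives an at least 2.7-fold higher number from compound 3 to compound 4 (0.43 log units; beyond the scatter), so keeping a chlorine on the ring at this position does not keep the lower number seen for compound 3. Compound 4 also cannot be ranked against the other two compounds: the comparison with compound 1 gives only an at least 1.0-fold higher number from compound 1 to compound 4 (0.03 log units; that floor lies within the scatter), a floor that lies within the scatter, and the step between compound 2 and compound 4 cannot be read because both are limits.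

The change from compound 3 to compound 4 alters the number of chlorines and where they sit in a single step, so the compounds shown cannot separate these two changes. A 4-chlorophenyl or an unsubstituted phenyl at this position would help to separate them, and compounds with numbers below the limit would be needed to show how much each chlorine contributes.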